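A few compounds are considered here, and "the series" means these few. Any claim that something is new, unique, unknown or untested is made for them only; others in the source may bear on it.

Three related compounds have been measured in a functional assay on EA.hy 926 cells (Homo sapiens), read by fluorescence, tested at 10 uM; on this read-out higher numbers stand for a stronger effect at the one concentration tested and lower numbers for a weaker effect. Compound 1, `CC(C)CNC(=C\C(=O)/C=C/c1ccc(O)cc1)/C=C/c1ccc(O)cc1`, gives 119%. Compound 3, `CCC(C)NC(=C\C(=O)/C=C/c1ccc(O)cc1)/C=C/c1ccc(O)cc1`, carries the change sec-butyl in place of isobutyl on an amine nitrogen relative to compound 1, and in this assay compound 3 gives 414%. That single change produced the step of a number 295 percentage points higher from compound 1 to compound 3 (beyond the scatter). Compound 2, `COc1cc(/C=C/C(=O)/C=C(/C=C/c2ccc(OC(C)=O)c(OC)c2)NCC(C)C)ccc1OC(C)=O`, differs from compound 1 in more than one place, and the difference between the two cores is not broken down here; in this assay compound 2 gives 240%, the second highest of the three numbers, separated from compound 1 and from compound 3 by more than the usual scatter.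

Compound 4, `CCC(C)NC(=C\C(=O)/C=C/c1ccc(OC(C)=O)c(OC)c1)/C=C/c1ccc(OC(C)=O)c(OC)c1`, is not yet measured. It stands to compound 2 as compound 3 stands to compound 1: the change is sec-butyl in place of isobutyl on an amine nitrogen, made at the same place, an amine nitrogen whose other neighbour is a double-bonded chain carbon, so it is the same change as the one already measured, seen here again on a different core. Going by the values given here, the only measured precedent is the large rise from compound 1 to compound 3; whether the core of compound 2 carries it in full is unknown, so some of that size is held back. The expected step is a number 200 percentage points higher from compound 2 to compound 4 (beyond the scatter), resting on the size of a number 295 percentage points higher from compound 1 to compound 3 (beyond the scatter). Compound 4 is therefore estimated at 440%, with the range 260% to 650% expected to hold most repeats.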

Compound 4, a percentage reported as activity, at one concentration (the size of the read-out at that concentration, not a potency): 105%
Compound 4: middle estimate off by 335 percentage points, on the high side; the measured number lies below the stated range.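

In this assay, sec-butyl in place of isobutyl on the amine nitrogen did not keep the direction it had on the first core, and the new result is a number 135 percentage points lower from compound 2 to compound 4 (beyond the scatter). The same change therefore cannot be carried from one core to the other in this series as a fixed increment, or even with a fixed sign, and the two steps disagree by more than scatter can account for: the same change on two cores in this assay, a number 295 percentage points higher (beyond the scatter) from compound 1 to compound 3 and a number 135 percentage points lower (beyond the scatter) from compound 2 to compound 4, 430 percentage points apart, beyond the scatter of two such steps. Going by these compounds alone, this does not show which of the differences between the two cores reverses the step or how the reversal comes about, and with only one step on each core it gives no rule for any further core, so neither direction can be called typical of the series.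

The compounds shown leave open whether the free hydroxyl, the acetate or the methoxy groups decide the direction, which a core with free hydroxyl and methoxy groups together could begin to separate. They also leave open how other groups on the same nitrogen, such as a straight butyl chain or a tert-butyl group, would behave on each core.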